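The compounds below may be only part of what the source reports. "The series", "measured", "known", "first", "only" and "open" are said of these compounds alone.

Compound 3 `CN(C)C(=O)c1cc2cnc(Nc3ccc(C(=O)NCCCCN=C=S)cc3)nc2n1C1CCCC1` gives 55.2% in a functional assay on NCI-H1299 cells (Homo sapiens) for inhibition, read by CCK-8 assay, with a stated time of 72 h, tested at 1 uM; a lower number here means a weaker effect, a higher number a stronger effect of the compound at the concentration tested. Among the three measured numbers it stands second highest: compound 1 `CN(C)C(=O)c1cc2cnc(Nc3ccc(S(=O)(=O)NCCCCCN=C=S)cc3)nc2n1C1CCCC1` gives 52.1%, within the scatter of compound 3, and compound 2 `CN(C)C(=O)c1cc2cnc(Nc3ccc(C(=O)NCCCN=C=S)cc3)nc2n1C1CCCC1` gives 65.1%, also within the scatter of compound 3. Compound 4 `CN(C)C(=O)c1cc2cnc(Nc3ccc(C(=O)NCCCCCN=C=S)cc3)nc2n1C1CCCC1` differs from compound 3 by a group of 4 heavy atoms (2 carbon, 1 nitrogen, 1 sulfur; no ring) in place of a group of 3 heavy atoms (1 carbon, 1 nitrogen, 1 sulfur; no ring), on a saturated chain carbon, four bonds along the chain from an amide-type nitrogen. For the measured compounds named here, the one measured step that exchanges the same kind of groups is a number 9.9 percentage points lower from compound 2 to compound 3 (within the scatter), a change within the scatter. The steps of a number 13 percentage points higher from compound 1 to compound 2 (beyond the scatter) and a number 3.1 percentage points higher from compound 1 to compound 3 (within the scatter) exchange a different part and bear less on it. From the earlier step, the expected change is a number 5.2 percentage points lower from compound 3 to compound 4 (within the scatter), nothing beyond the scatter. Compound 4 is therefore estimated at 50%, between 36% and 64%.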

Compound 4, a percentage reported as inhibition, at one concentration (the size of the read-out at that concentration, not a potency): 50.3%
Compound 4: the middle estimate sits 0.3 percentage points below what was measured, within the range that was stated.
By their numbers in this assay, from the lowest: compounds 4, 1, 3 and 2 (each within the scatter of the next, the first and the last beyond it).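

In this assay, the further extension of the chain gives a number 4.9 percentage points lower from compound 3 to compound 4 (within the scatter), a step within the scatter, but the whole extension gives a number 14.8 percentage points lower from compound 2 to compound 4 (beyond the scatter), which is beyond it, so only the two steps taken together separate these chain lengths. At this chain length, exchanging the amide for the sulfonamide gives only a number 1.8 percentage points lower from compound 1 to compound 4 (within the scatter), also within the scatter. No available evidence accounts for either result. The compounds shown leave open whether a longer chain would continue this trend. They also leave open how a primary amine or a carboxylic acid at the chain end would compare.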